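Adding an acetylpiperazine to a substance-P antagonist core

The source may hold more compounds than are shown below. What is called first, only, known or untested is meant among the compounds shown, and "the series" means these compounds.

Compounds measured so far:
compound 1, `CC(=O)N1CCN(c2nc3c(c(-c4ccccc4C)n2)C(=O)N(Cc2cc(C(F)(F)F)cc(C(F)(F)F)c2)C[C@H](C)CO3)CC1`, 0.139 nM
compound 2, `Cc1ccccc1-c1ncnc2c1C(=O)N(Cc1cc(C(F)(F)F)cc(C(F)(F)F)c1)CCCO2`, 11.6 nM

Both compounds were tested in a functional assay on ileum for antagonist activity at Substance-P receptor (Cavia porcellus); on this read-out lower numbers stand for stronger inhibition and higher numbers for weaker inhibition. Compound 2 gives 11.6 nM, the higher of the two numbers, and compound 1 gives 0.139 nM, the lower. Compound 1 also carries a methyl on its non-aromatic ring, so the two differ in more than one place.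

Compound 3, `CC(=O)N1CCN(c2nc3c(c(-c4ccccc4C)n2)C(=O)N(Cc2cc(C(F)(F)F)cc(C(F)(F)F)c2)CCCO3)CC1`, has not yet been measured. It differs from compound 2 by 4-acetylpiperazin-1-yl in place of hydrogen on an aromatic carbon. Among the measured compounds shown here, the only guide is compound 1, which carries the same 4-acetylpiperazin-1-yl group and gives 0.139 nM. On that basis, the step of a 39-fold lower number from compound 2 to compound 3 (1.59 log units; beyond the scatter) is expected to be large, towards stronger inhibition. Compound 3 is estimated at 0.3 nM, within a range from 0.08 nM to 1.5 nM.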

Compound 3, antagonist equilibrium constant: 0.105 nM
Compound 3: the middle estimate sits 2.9-fold (0.46 log units) above what was measured; the measured number falls inside the stated range.
By their numbers in this assay, from the lowest: compounds 3 and 1 (each within the scatter of the next); then compound 2.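

In this assay, among the compounds shown here, putting 4-acetylpiperazin-1-yl in place of hydrogen on the aromatic carbon between two ring nitrogen atoms gives a large gain (a 110-fold lower number from compound 2 to compound 3 (2.04 log units; beyond the scatter)), and this is the first reading of that change alone, since compound 1 and compound 2 differ in more than one place. The methyl on the saturated ring carbon, the other difference between those two, makes no difference that can be told from scatter (a 1.3-fold lower number from compound 1 to compound 3 (0.12 log units; within the scatter)), so the gap between them can be traced to the added group. Nothing measured here explains why this group has so large an effect.

For the compounds shown here, only one group is seen at this carbon, so it remains open whether a piperazine without the acetyl, a morpholine or a dimethylamino group would do the same. On these data alone, the reading on the methyl comes from one pair, and it remains open whether it would hold on compound 2, where the 4-acetylpiperazin-1-yl group is absent.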